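Extending a Pyridine Core Toward an Unmeasured Analogue

This account rests on a few compounds, and the source may have more. Where it says the series, first, only, none or still open, it means among the compounds named here.

Compound 1, with the structure `c1coc(-c2ccnc(-c3cccs3)c2)c1`, was tested in a functional assay on SK-MEL-2 cells (Homo sapiens) for antiproliferative activity; on this read-out lower numbers stand for an effect already at smaller amounts and higher numbers for an effect only at larger amounts of compound. In this assay compound 1 gives 118000 nM. Going by the values given here, the only other measured compound is compound 2, built as `C(=C/c1cccs1)\c1cc(-c2cccs2)cc(-c2cccs2)n1`, and in this assay compound 2 gives 118000 nM. On these numbers compound 1 stands level with compound 2; the two values agree at the digits shown and lie within the usual scatter of each other, so no order between them can be read.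

Compound 3, drawn as `C(=C/c1ccco1)\c1cc(-c2ccco2)cc(-c2cccs2)n1`, has not been measured. It differs from compound 1 in one place: 2-(furan-2-yl)ethenyl in place of hydrogen on an aromatic carbon, placed on an aromatic carbon of the six-membered ring with one nitrogen, next to the ring nitrogen and meta to both the furan-2-yl and the thiophen-2-yl group. Among the compounds with values here, no measured pair shows this exact step. Compound 2, which also carries an ethenyl-linked five-membered ring on the same kind of core, sits at 118000 nM, the same reading as compound 1, so the step from compound 1 to compound 3 is expected to be no change at the digits printed from compound 1 to compound 3 (within the scatter), meaning no change beyond the scatter in either direction. Compound 3 is therefore expected to give about 118000 nM in this assay, within a range from 50000 nM to 250000 nM.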

Compound 3, half-maximal effective concentration: 118000 nM
Estimate against measurement, compound 3: no gap at the digits printed; low and high end bracket the measured number.
By their numbers in this assay, from the lowest: compounds 1, 2 and 3 (each within the scatter of the next).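

In this assay, putting 2-(furan-2-yl)ethenyl in place of hydrogen on the aromatic carbon next to the ring nitrogen brings no change at the digits printed from compound 1 to compound 3 (within the scatter). Going by these compounds alone, this is the first step read directly at this position, and it shows that adding 7 heavy atoms there, including a five-membered aromatic ring and a double bond outside aromatic rings, leaves the reading within the scatter of the unsubstituted compound. Nothing measured here explains why the reading stays the same.

A single group cannot show whether this position is insensitive to change in general or whether only 2-(furan-2-yl)ethenyl leaves the number where it was. An amine, a carboxylic acid or a simple methyl group on the same carbon would test whether anything placed there can move the reading away from that of compound 1 at 118000 nM and in which direction.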